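The source may report more compounds than this note shows. Statements on the series, on what has been measured and on what is new or still open speak of the compounds shown alone.

Of the compounds shown here, two from this series have been measured in a functional assay on HepG2 cells (Homo sapiens) for inhibition, read by MTT assay, with a stated time of 48 h; a higher number here means a weaker inhibitor, a lower number a stronger inhibitor. Compound 1, `Brc1ccc(CSc2nnc(-c3ccncc3)n2-c2ccccc2)cc1`, carries a 4-bromophenyl group joined through a sulfur-linked methylene to the shared core; in this assay compound 1 gives 12900 nM. Compound 2, `O=C(CSc1nnc(-c2ccncc2)n1-c1ccccc1)N/N=C/c1ccc(Br)cc1`, keeps the same core but attaches the 4-bromophenyl group through an acylhydrazone chain; in this assay compound 2 gives 5990 nM. Among the measured compounds shown here, of the two numbers, the one for compound 2 is the lower, and the gap between them lies beyond the usual scatter, so compound 2 stands as the stronger inhibitor of the pair.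

Compound 3, `O=C(CSc1nnc(-c2ccncc2)n1-c1ccccc1)N/N=C/c1cc(Br)ccc1O`, has not yet been measured. It differs from compound 2 in one place: 5-bromo-2-hydroxyphenyl in place of 4-bromophenyl on a carbon with a double bond to nitrogen. For the measured compounds named here, whether the added hydroxyl group and the shifted bromine will change the number is unknown, since no step between measured compounds speaks to it. The step from compound 2 to compound 3 is expected to be small, a 1.3-fold lower number from compound 2 to compound 3 (0.12 log units; within the scatter), and is not expected to reach beyond the scatter. For compound 3 in this assay the estimate is 4500 nM, with a likely range from 1500 nM to 13000 nM.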

Compound 3, half-maximal inhibitory concentration: 4390 nM
Compound 3: middle estimate off by 1.0-fold (0.01 log units), on the high side; the measured number falls inside the stated range.
By their numbers in this assay, from the lowest: compounds 3 and 2 (each within the scatter of the next); then compound 1.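

On a carbon with a double bond to nitrogen, 5-bromo-2-hydroxyphenyl in place of 4-bromophenyl gives a 1.4-fold lower number from compound 2 to compound 3 (0.13 log units; within the scatter) in this assay. Among the compounds shown here, this is the first step that changes only one place, and it shows that this end of the acylhydrazone chain can take on a hydroxyl group, with one more hydrogen-bond donor and one more hydrogen-bond acceptor, and a bromine at a different ring position without a difference that stands out from repeat measurements. No separate measurement bears on why the two numbers stay so close.

The step combines two differences, so it cannot say what the hydroxyl group and the shifted bromine each contribute, or whether their contributions offset each other or are both small. Also open, as far as these compounds go, is whether an amine, a methoxy group or a carboxylic acid in place of that hydroxyl group would carry the number beyond the scatter.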